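A Piperazine for a Dimethylamino on a Weak Antiproliferative Series

This account rests on a few compounds, and the source may have more. Where it says the series, first, only, none or still open, it means among the compounds named here.

Compound 1 `COc1ccc(-c2cc3ccc(OC)cc3nc2Nc2ccc(NC(=O)CN(C)C)cc2)cc1` gives 9200 nM in a functional assay on HUVEC cells (Homo sapiens) for antiproliferative activity, read by MTT assay, with a stated time of 48 h; on this read-out higher numbers stand for weaker inhibition and lower numbers for stronger inhibition.
Compound 2 `CCN(CC)CC(=O)Nc1ccc(Nc2nc3cc(OC)ccc3cc2-c2ccc(OC)cc2)cc1` gives 14000 nM in this assay.
Compound 3 `COc1ccc(-c2cc3cc(OC)ccc3nc2Nc2ccc(NC(=O)CN(C)C)cc2)cc1` gives 22200 nM in this assay.

In this assay compound 3 stands at the highest of the three numbers: its gap to compound 2 lies within the scatter, its gap to compound 1 beyond it. Compound 4 `COc1ccc(-c2cc3cc(OC)ccc3nc2Nc2ccc(NC(=O)CN3CCN(C)CC3)cc2)cc1` differs from compound 3 by 4-methylpiperazin-1-yl in place of dimethylamino on a saturated chain carbon bound to a carbonyl carbon. For the measured compounds named here, the only measured step at that same place is a 1.5-fold higher number from compound 1 to compound 2 (0.18 log units; within the scatter), an enlargement of the amine end that stayed within the scatter. Compound 4 is therefore expected to show no step beyond the scatter, a 1.1-fold higher number from compound 3 to compound 4 (0.05 log units; within the scatter). The estimate for compound 4 is 25000 nM, with a range from 10000 nM to 60000 nM.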

Compound 4, half-maximal inhibitory concentration: 7400 nM
Beside the measured number, compound 4's estimate is 3.4-fold (0.53 log units) above it, outside the stated range (below it).
By their numbers in this assay, from the lowest: compounds 4, 1, 2 and 3 (each within the scatter of the next, the first and the last beyond it).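

At this place, on a saturated chain carbon bound to a carbonyl carbon, this assay does respond to the amine end: the change to 4-methylpiperazin-1-yl gives a 3.0-fold lower number from compound 3 to compound 4 (0.48 log units; beyond the scatter). For the compounds shown here, the earlier change to diethylamino, a 1.5-fold higher number from compound 1 to compound 2 (0.18 log units; within the scatter), gave no such step, so enlarging this end does not by itself settle the outcome. No evidence at hand accounts for the step.

Still open, from the compounds shown here alone, is whether the ring or its methyl group carries the step, which an unsubstituted piperazine, a morpholine or a piperidine at this place could separate. Also open, going by these compounds, is whether 4-methylpiperazin-1-yl gives a similar step on the core of compound 1.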